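The compounds below may be only part of what the source reports. "The series", "measured", "known", "first", "only" and "open" are said of these compounds alone.

Measured so far in a functional assay on A549 cells (Homo sapiens) for cytotoxicity, read by MTT assay, with a stated time of 72 h; a lower number here means a stronger inhibitor, a higher number a weaker inhibitor:
- compound 1 `COc1cccc(/C=C2\CCC/C(=C\c3ccc(Cl)cc3)C2=O)c1OC`: > 20000 nM
- compound 2 `COc1cccc(/C=C2\CCC/C(=C\c3cccc(OC)c3OC)C2=O)c1`: 16400 nM
- compound 3 `COc1ccc(/C=C2\CCC/C(=C\c3ccc(Cl)cc3)C2=O)cc1OC`: 10100 nM

The value of compound 1 is a limit of this assay, not a number, the line the limit of > 20000 nM in this assay, at which 1 of the 3 values shown sits, being the only limit among the three results. Compound 3 gives the lowest of the two numbers, with compound 2 nearest; that gap lies within the scatter, so no order between the two can be read.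

Compound 4 `COc1ccc(/C=C2\CCC/C(=C\c3ccc(O)c(O)c3)C2=O)cc1OC` is not yet measured. It differs from compound 3 by 3,4-dihydroxyphenyl in place of 4-chlorophenyl on a double-bonded chain carbon bound to a double-bonded ring carbon. Among the measured compounds shown here, the one measured step that touches the same position is an at least 1.2-fold lower number from compound 1 to compound 2 (0.08 log units; that floor lies within the scatter), a change with a floor inside the scatter. For the measured compounds named here, no measured step shows a 3,4-dihydroxyphenyl group, so the expectation rests on that single step alone. Compound 4 is therefore expected to give about 8000 nM, between 3000 nM and 22000 nM, a step of a 1.3-fold lower number from compound 3 to compound 4 (0.10 log units; within the scatter) that is expected to stay within the scatter.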

Compound 4, half-maximal inhibitory concentration: > 20000 nM
Compound 4 gave a limit, no number; the forecaster's own chance of this, stated with the estimate: 20%; middle value at least 2.5-fold (0.39 log units) away from the limit.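

In this assay, 3,4-dihydroxyphenyl in place of 4-chlorophenyl on a double-bonded chain carbon bound to a double-bonded ring carbon gives an at least 1.9-fold higher number from compound 3 to compound 4 (0.29 log units; that floor lies within the scatter), so a rise is not established, but this change brings no lower number. Compound 4 gives a limit of the assay, not a number: the limit of > 20000 nM in this assay, at which 2 of the 4 values shown sit.

Open, on these data alone, is how an amine or a carboxylic acid on the phenyl group at this place would read in this assay. Also open, as far as these compounds go, is whether a single hydroxyl group there would read like 3,4-dihydroxyphenyl.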